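Swapping fluoro for chloro in a flat series

The source may report more compounds than this note shows. Statements on the series, on what has been measured and on what is new or still open speak of the compounds shown alone.

In a functional assay on DU-145 cells (Homo sapiens) for inhibition, read by trypan blue exclusion, with a stated time of 96 h (a lower number here means a stronger inhibitor of growth, a higher number a weaker inhibitor of growth), compound 1 `O=C(O)c1ccc(C(=O)/C(=C\c2ccc(F)c([N+](=O)[O-])c2)SCc2ccc(Cl)cc2Cl)cc1` gives 1000 nM, compound 2 `O=C(O)c1ccc(C(=O)/C(=C\c2ccc(Cl)c([N+](=O)[O-])c2)SCc2ccc(Cl)cc2)cc1` gives 1000 nM and compound 3 `O=C(O)c1ccc(C(=O)/C(=C\c2ccc(F)c([N+](=O)[O-])c2)SCc2ccc(C(F)(F)F)cc2)cc1` gives 1000 nM, so compound 3 stands level with both. Compound 4 `O=C(O)c1ccc(C(=O)/C(=C\c2ccc(Cl)c([N+](=O)[O-])c2)SCc2ccc(C(F)(F)F)cc2)cc1` differs from compound 3 in one place: chloro in place of fluoro on an aromatic carbon. Within the data shown here, the one measured step, no change at the digits printed from compound 1 to compound 3 (within the scatter), concerns another group, 4-(trifluoromethyl)phenyl in place of 2,4-dichlorophenyl, and shows no shift. Compound 2 already carries the 4-chloro-3-nitrophenyl group and gives 1000 nM, the same value as the others. The expected result is no change at the digits printed from compound 3 to compound 4 (within the scatter), with no shift beyond the scatter. Compound 4 is expected at 1000 nM, with an estimated range of 500 nM to 2000 nM.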

Compound 4, concentration for 50% growth inhibition: 1000 nM
Compound 4: the middle estimate sits on the measured number at the digits printed; the measured number falls inside the stated range.
By their numbers in this assay, from the lowest: compounds 1, 2, 3 and 4 (each within the scatter of the next).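

Chloro and fluoro on this aromatic carbon, ortho to a nitro group, cannot be told apart in this assay: the change gives no change at the digits printed from compound 3 to compound 4 (within the scatter). With the 4-chloro-3-nitrophenyl group kept, trifluoromethyl in place of chloro on the other aromatic ring also gives no change at the digits printed from compound 2 to compound 4 (within the scatter), so the swap holds up against two different partners. No measured evidence offers a reason for this flat result. Still open, going by these compounds, is whether an amine or a methoxy group in place of the halogen on this carbon would read differently.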